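Sulfonylurea chain extension: compound 2 to compound 3

The source may report more compounds than this note shows. Statements on the series, on what has been measured and on what is new or still open speak of the compounds shown alone.

Two sulfonylureas on the shared core have been measured in an assay on microsomes from intestine for inhibition of acyl-CoA:cholesterol acyltransferase (Oryctolagus cuniculus); a lower number here means a stronger inhibitor, a higher number a weaker inhibitor. Compound 1 `CCCCCCCCCCS(=O)(=O)NC(=O)Nc1c(C(C)C)cccc1C(C)C` gives 11100 nM in this assay. Compound 2 `CCCCCCCCCCCCCCS(=O)(=O)NC(=O)Nc1c(C(C)C)cccc1C(C)C`, in this assay, gives 830 nM. For the measured compounds named here, compound 2 therefore holds the lowest of the two numbers so far; its nearest neighbour is compound 1, and the step between them, a 13-fold lower number from compound 1 to compound 2 (1.13 log units; beyond the scatter), comes from butyl in place of hydrogen on a saturated chain carbon, ten or more bonds along the chain from a sulfonyl sulfur.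

Compound 3 `CCCCCCCCCCCCCCCCS(=O)(=O)NC(=O)Nc1c(C(C)C)cccc1C(C)C` is not yet measured in this assay. It differs from compound 2 by ethyl in place of hydrogen on a saturated chain carbon, ten or more bonds along the chain from a sulfonyl sulfur; the same difference, cut one bond further out, reads methyl to propyl, ethyl to butyl, propyl to pentyl. Going by the values given here, the only step that bears on this change is a 13-fold lower number from compound 1 to compound 2 (1.13 log units; beyond the scatter), a large one in the same direction of chain lengthening, though by a longer piece than is added here. A further lowering is expected for compound 3, a 2.4-fold lower number from compound 2 to compound 3 (0.38 log units; beyond the scatter), smaller than that earlier step. Compound 3 is thus estimated at 350 nM in this assay, with a range from 120 nM to 1100 nM.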

Compound 3, half-maximal inhibitory concentration: 1350 nM
Compound 3: middle estimate off by 3.9-fold (0.59 log units), on the low side; the whole stated range lies below it.
By their numbers in this assay, from the lowest: compounds 2 and 3 (each within the scatter of the next); then compound 1.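

In this assay, ethyl in place of hydrogen on a saturated chain carbon, ten or more bonds along the chain from a sulfonyl sulfur, gives a 1.6-fold higher number from compound 2 to compound 3 (0.21 log units; within the scatter) and so separates the chains of these two compounds by nothing that can be read. Set against the large step from compound 1 to compound 2, this shows that the lowering seen with the butyl change does not carry on with the further ethyl change, and compound 3 goes against any steady fall with chain length. The longer chain keeps its distance from the shortest one, with an 8.2-fold lower number from compound 1 to compound 3 (0.91 log units; beyond the scatter) as a modest step, but no measurement shown here gives a reason for the levelling.

The three compounds leave open whether a longer chain than that of compound 3 would stay level with compounds 2 and 3 or move away from them in this assay in either direction. They also leave open how a carboxylic acid or an amine at the far end of the chain would read against this level, since every chain shown is plain saturated carbon.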